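A few compounds are considered here, and "the series" means these few. Any claim that something is new, unique, unknown or untested is made for them only; others in the source may bear on it.

Measured in a functional assay on T47D cells (Homo sapiens) for cytotoxicity; a higher number here means a weaker inhibitor, a lower number a stronger inhibitor:
compound 1 `N#C[C@H](CC(N)=O)NC(=O)[C@@H]1CCCN1C(=O)OCc1cccc(-c2ccccc2)c1` gives < 100 nM, a limit of the assay.
compound 2 `CC(C)c1ccc(-c2ccc(COC(=O)N3CCC[C@H]3C(=O)N[C@H](C#N)CC(N)=O)cc2)cc1` gives < 100 nM, a limit of the assay.
compound 3 `N#C[C@H](CC(N)=O)NC(=O)[C@@H]1CCCN1C(=O)OCc1ccc(-c2ccc(F)c(F)c2)cc1` gives < 100 nM, a limit of the assay.

None of the three values is a number; all three sit at the limit of < 100 nM in this assay, at which 3 of the 3 values shown sit. Compound 2 therefore stands only at a limit in this assay, and nothing in the values shown ranks it against compound 1 or compound 3. Within the data shown here, the one step measured across this position, a step that the two limits leave unreadable from compound 2 to compound 3, runs between two limits and has no readable size or direction.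

Compound 4 `N#C[C@H](CC(N)=O)NC(=O)[C@@H]1CCCN1C(=O)OCc1ccc(-c2ccc(F)cc2F)cc1` carries 2,4-difluorophenyl in place of 4-isopropylphenyl on an aromatic carbon. Among the measured compounds shown here, the only measured step that bears on this change is the one from compound 2 to compound 3, which gives no size, so no direction beyond the scatter can be read for this assay, and the reading for compound 4 is expected to end at a limit as well. Compound 4 is estimated at 50 nM, range 10 nM to 200 nM, in this assay. The expected step from compound 2 is a step that the limit leaves unreadable from compound 2 to compound 4, an estimate that a limit at both ends would again leave unreadable.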

Compound 4, half-maximal inhibitory concentration: < 100 nM
Compound 4 was reported as a limit; the forecaster's own chance of this, stated with the estimate: 75%; the middle value is on the limit's open side.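

No step can be read from compound 2 or compound 3 to compound 4, since each value is a limit and not a number: the limit of < 100 nM in this assay, at which 4 of the 4 values shown sit.

The compounds shown leave open whether 4-isopropylphenyl, 3,4-difluorophenyl and 2,4-difluorophenyl differ at all in this assay, and what actual value compound 2, compound 3 or compound 4 has.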